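Working notes: one further chain extension

This account rests on a few compounds, and the source may have more. Where it says the series, first, only, none or still open, it means among the compounds named here.

In a physicochemical assay for lipophilicity (on this read-out lower numbers stand for lower lipophilicity and higher numbers for higher lipophilicity), compound 1 `CCCCCCCCn1c(N)c(N)c(=O)[nH]c1=O` gives 2.05 and compound 2 `CCCCCCCCn1c(=O)[nH]c(=O)c2[nH]c(O)nc21` gives 1.1. Compound 3 `CCCCCCCCCCn1c(=O)[nH]c(=O)c2[nH]c(O)nc21` gives 2.04, within the scatter of compound 1 and well above compound 2. The change to compound 4 `CCCCCCCCCCCCn1c(=O)[nH]c(=O)c2[nH]c(O)nc21` is ethyl in place of hydrogen on a saturated chain carbon, ten or more bonds along the chain from an aromatic nitrogen. Among the compounds with values here, the only measured step of this kind, eight bonds along the chain, is a number 0.94 log units higher from compound 2 to compound 3 (beyond the scatter), modest but beyond the scatter. Within the data shown here, compound 1 carries a different core and offers no comparable step. On that single step, a rise of similar size is expected in this assay, the estimated step being a number 0.94 log units higher from compound 3 to compound 4 (beyond the scatter). For compound 4 the estimate is 2.98, with an expected range of 2.6 to 3.4.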

Compound 4, partition coefficient: 2.9
Compound 4: the middle estimate sits 0.08 log units above what was measured; the range from low to high includes it.
By their numbers in this assay, from the lowest: compound 2; then compounds 3 and 1 (each within the scatter of the next); then compound 4.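

In this assay, the rise first seen eight bonds along the chain recurs further out: ethyl in place of hydrogen on a saturated chain carbon gives a number 0.86 log units higher from compound 3 to compound 4 (beyond the scatter) and stays beyond the scatter. Read as one change, butyl in place of hydrogen gives a number 1.80 log units higher from compound 2 to compound 4 (beyond the scatter) and is large. No supporting measurement bears on what lies behind these steps.

On these data alone, whether a still longer chain continues the rise remains open. So does what an amine or a carboxylic acid on the chain would give.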